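Swapping the Basic Tail of Compound 3

This account rests on a few compounds, and the source may have more. Where it says the series, first, only, none or still open, it means among the compounds named here.

Measured so far in a functional assay on U-937 cells (Homo sapiens) for cytotoxicity, read by WST assay, with a stated time of 72 h; on this read-out higher numbers stand for weaker inhibition and lower numbers for stronger inhibition:
Compound 1, `COc1cc2c(Nc3nc4ccc(C(=O)Nc5c(C)cccc5Cl)cc4s3)ncnc2cc1OCCCN1CCCCC1C`, gives 7000 nM.
Compound 2, `COc1cc2c(Nc3nc4ccc(C(=O)Nc5c(C)cccc5C)cc4s3)ncnc2cc1OCCCN1CCCCC1C`, gives 10800 nM.
Compound 3, `COc1cc2c(Nc3nc4ccc(C(=O)Nc5c(C)cc(C)cc5C)cc4s3)ncnc2cc1OCCCN1CCCCC1C`, gives 3600 nM.

Compound 3 carries the smallest of the three numbers, but only one of its two gaps is meaningful: a 1.9-fold lower number from compound 1 to compound 3 (0.29 log units; within the scatter), whereas a 3.0-fold lower number from compound 2 to compound 3 (0.48 log units; beyond the scatter). The next compound, compound 4, `CCN(CC)CCCOc1cc2ncnc(Nc3nc4ccc(C(=O)Nc5c(C)cc(C)cc5C)cc4s3)c2cc1OC`, differs from compound 3 in a single place: diethylamino in place of 2-methylpiperidin-1-yl on a saturated chain carbon, three bonds along the chain from an oxygen on an aromatic ring. Within the data shown here, no measured step touches this part of the molecule; all three steps change the aromatic amide substituent, and the tail is identical across compounds 1, 2 and 3. There is thus nothing to lean on, and the plainest expectation is that the number stays roughly where it is. Compound 4 is expected to give 4500 nM, with a range of 1800 nM to 12000 nM, an expected step of a 1.3-fold higher number from compound 3 to compound 4 (0.10 log units; within the scatter) that should remain within the scatter.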

Compound 4, half-maximal inhibitory concentration: 4300 nM
For compound 4 the middle estimate is 1.0-fold (0.02 log units) above the measured one; the measured number falls inside the stated range.
By their numbers in this assay, from the lowest: compounds 3, 4, 1 and 2 (each within the scatter of the next, the first and the last beyond it).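

Among these compounds, until now every step changed the aromatic amide substituent, so this is the first reading on the basic tail, and in this assay it shows a 1.2-fold higher number from compound 3 to compound 4 (0.08 log units; within the scatter). For this pair, the ring-free diethylamino, with 5 heavy atoms, therefore serves as well as the ringed 2-methylpiperidin-1-yl, with 7. No supporting evidence accompanies this result.

On these data alone, it remains open whether a tail ending in morpholin-4-yl or 4-methylpiperazin-1-yl would also leave the number within the scatter. The same question applies to a shorter chain joining the amine to the oxygen.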